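The compounds below may be only part of what the source reports. "The series", "measured", "known", "first", "only" and "open" are said of these compounds alone.

This piece follows three compounds tested in a toxicity assay on NIH3T3 cells (Mus musculus) for cytotoxicity, read by resazurin assay (on this read-out lower numbers stand for an effect already at smaller amounts and higher numbers for an effect only at larger amounts of compound), and a fourth not yet tested there. Compound 1 `c1ccc(Cn2cncc2CNc2cccc(-c3ccccc3)c2)cc1` carries a phenyl on an aromatic carbon. In this assay compound 1 gives > 750 nM, which is a limit of the assay and not a number. Compound 2 `Cc1cccc(-c2cccc(NCc3cncn3Cc3ccccc3)c2)c1C` has a 2,3-dimethylphenyl in place of that phenyl. Compound 2 gives > 1000 nM, again a limit. The step that the two limits leave unreadable from compound 1 to compound 2 therefore cannot be read in size or direction. Compound 3 `COC(=O)c1ccc(NCc2cncn2Cc2cccc(Cl)c2)cc1-c1ccccc1` gives > 10000 nM, also a limit, so compound 3 stands on a limit like the other two, and the three values cannot be ordered against each other. Compound 4 `COC(=O)c1ccc(NCc2cncn2Cc2ccccc2C)cc1-c1ccccc1` differs from compound 3 by 2-methylphenyl in place of 3-chlorophenyl on a saturated chain carbon bound to an aromatic nitrogen. For the measured compounds named here, no measured step bears directly on this change: the single measured step is unreadable and all three values are limits, so no step beyond the scatter can be expected in either direction. Compound 4 is expected to behave much like compound 3, with the step that the limit leaves unreadable from compound 3 to compound 4 estimated to be small. The estimate for compound 4 in this assay is 12000 nM, within 3000 nM to 40000 nM, most likely reported again only as a limit.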

Compound 4, half-maximal effective concentration: 10000 nM
For compound 4 the middle estimate is 1.2-fold (0.08 log units) above the measured one; the range from low to high includes it.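

In this assay compound 4 gives 10000 nM, the only plain number among the compounds shown, so with 2-methylphenyl at this place the read-out gives a measured value for the first time in this set rather than a limit. The change from 3-chlorobenzyl to 2-methylbenzyl thus gives a number no higher from compound 3 to compound 4 (the limit leaves the size open), which fixes the direction as no rise but says nothing firm about how far the two compounds lie apart. The gap between them cannot be read because compound 3 stands on a limit, not a number: the limit of > 10000 nM in this assay, at which 1 of the 4 values shown sits.

The compounds shown leave open how this place responds to a group of a different kind, such as an amine or a carboxylic acid on the ring, or a longer chain carrying the ring further out. Also open, from the compounds shown here alone, is whether 2-methylphenyl at this place would give a plain number on the core of compound 1 as well, and so whether this result holds beyond the core of compound 3.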